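The source may report more compounds than this note shows. Statements on the series, on what has been measured and on what is new or still open speak of the compounds shown alone.

In an ADME assay on HeLa cells (Homo sapiens) for cytotoxicity, read by ATP content, with a stated time of 3 days (on this read-out higher numbers stand for lower toxicity in this test and lower numbers for higher toxicity in this test), three compounds of one family have been tested so far. Compound 1 `CS(=O)(=O)CCCn1c(Cn2c(=O)n(C3CC3)c3ccncc32)cc2ccccc21` reaches only the limit of this test, > 100000 nM. Compound 2 `O=C(O)CCCn1c(Cn2c(=O)n(C3CC3)c3ccncc32)cc2cc(Cl)ccc21` likewise stops at a limit, > 50000 nM. Compound 3 `CC(C)CCn1c(Cn2c(=O)n(C3CC3)c3ccncc32)cc2cnccc21` also gives a limit, > 50000 nM. Compound 2 therefore sits at a limit that two of the three values share (the limit of > 50000 nM in this assay, at which 2 of the 3 values shown sit), while one value sits at another limit (the limit of > 100000 nM in this assay, at which 1 of the 3 values shown sits). Compound 4 `CC(C)(O)CCCn1c(Cn2c(=O)n(C3CC3)c3ccncc32)cc2cc(Cl)ccc21` differs from compound 2 by 1-hydroxy-1-methylethyl in place of carboxy on a saturated chain carbon, three bonds along the chain from an aromatic nitrogen. Among the compounds with values here, no step between measured compounds is known, and none of the three showed measurable toxicity. The change is expected to bring no step beyond the scatter, a step that the limit leaves unreadable from compound 2 to compound 4. Compound 4 is estimated at 60000 nM, between 20000 nM and 100000 nM, most likely reported again only as a limit.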

Compound 4, half-maximal cytotoxic concentration: > 50000 nM
Compound 4 gave a limit, no number; the forecaster's own chance of this, stated with the estimate: 85%; the middle value is on the limit's open side.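

Compound 2 and compound 4 both give only a limit, and no step can be read between them. The compounds shown leave open at what concentration, if any, each of them would become toxic to these cells.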